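Removing the pentafluorosulfanyl group from compound 1

The source may hold more compounds than are shown below. What is called first, only, known or untested is meant among the compounds shown, and "the series" means these compounds.

Compound 1: `O=C(NO)c1ccc(Cn2nnc(-c3cccc(S(F)(F)(F)(F)F)c3)n2)cc1`, 26 nM
Compound 2: `Cn1c(Cc2ccc(C(=O)NO)cc2)nnc1-c1ccccc1`, 17 nM
Compound 3: `NCc1ccc(-c2nnn(Cc3c(F)cc(C(=O)NO)cc3F)n2)cc1`, 4 nM

In an assay on Sf9 cells for inhibition of protein deacetylase HDAC6 (Homo sapiens), read by fluorescence (on this read-out lower numbers stand for stronger inhibition and higher numbers for weaker inhibition), compound 1 gives 26 nM, the highest of the three numbers. Compound 2 gives 17 nM, which sits within the scatter of compound 1. Compound 3 gives 4 nM, a gap from compound 1 that lies beyond the scatter. Compound 4 `O=C(NO)c1ccc(Cn2nnc(-c3ccccc3)n2)cc1` has not yet been measured. It differs from compound 1 in one place: a hydrogen atom in place of a group of 6 heavy atoms (5 fluorine, 1 sulfur; no ring), on an aromatic carbon. For the measured compounds named here, with no step between measured compounds of this kind available, the expectation rests on compound 2, whose value 17 nM also comes from a compound with no substituent on that ring. Compound 4 is expected to show a step of a 1.5-fold higher number from compound 1 to compound 4 (0.19 log units; within the scatter), a modest weakening, near or within the scatter. The estimate for compound 4 is 40 nM, within 15 nM to 110 nM.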

Compound 4, half-maximal inhibitory concentration: 3 nM
Compound 4: the middle estimate sits 13-fold (1.12 log units) above what was measured, outside the stated range (below it).
By their numbers in this assay, from the lowest: compounds 4 and 3 (each within the scatter of the next); then compounds 2 and 1 (each within the scatter of the next).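

In this assay, putting a hydrogen atom in place of the group of 6 heavy atoms (5 fluorine, 1 sulfur) gives an 8.7-fold lower number from compound 1 to compound 4 (0.94 log units; beyond the scatter). For the compounds shown here, this is the first direct reading at this aromatic carbon, and it shows that, on the core of compound 1, the unsubstituted ring gives the lower number. Nothing measured here accounts for the size of this step.

With only these two groups shown at this carbon, it stays open whether a methyl group, a chlorine atom or a methoxy group would give a number nearer compound 4 or compound 1. As far as these compounds go, whether the same step would appear at the other carbons of that ring also stays open.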